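Compound 4: a 3,4-Dimethylphenyl Change from Compound 1

The source may hold more compounds than are shown below. What is called first, only, known or untested is meant among the compounds shown, and "the series" means these compounds.

Compound 1 `N#CC1=C(N)Oc2c(c3nc4ccccc4nc3c3ccccc23)C12C(=O)N(Cc1cnnn1-c1ccc(Cl)cc1)c1ccccc12` was tested in a functional assay on HCT-116 cells (Homo sapiens) for antiproliferative activity, read by MTT assay, with a stated time of 48 h; a lower number here means a stronger inhibitor, a higher number a weaker inhibitor. Compound 1 reached only the limit of the assay, > 50000 nM, so no number is known for it. Two other compounds share its core and differ only in the group on the aromatic nitrogen. Compound 2 `N#CC1=C(N)Oc2c(c3nc4ccccc4nc3c3ccccc23)C12C(=O)N(Cc1cnnn1-c1ccccc1Br)c1ccccc12` likewise gave only a limit in this assay, > 50000 nM. Compound 3 `N#CC1=C(N)Oc2c(c3nc4ccccc4nc3c3ccccc23)C12C(=O)N(Cc1cnnn1-c1cccc(S(N)(=O)=O)c1)c1ccccc12` gave 11300 nM in this assay. Among the measured compounds shown here, the step between the two limits is a step that the two limits leave unreadable from compound 1 to compound 2, and the step to the sulfamoyl compound is an at least 4.4-fold lower number from compound 1 to compound 3 (0.64 log units; beyond the scatter), the one change that produced a readable number.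

Compound 4 `Cc1ccc(-n2nncc2CN2C(=O)C3(C(C#N)=C(N)Oc4c3c3nc5ccccc5nc3c3ccccc43)c3ccccc32)cc1C` differs from compound 1 as follows: 3,4-dimethylphenyl in place of 4-chlorophenyl on an aromatic nitrogen. The measured steps that bear on this are the unreadable one between the two halophenyl compounds and the downward one towards the 3-sulfamoylphenyl compound. The 3,4-dimethylphenyl group carries no donor or acceptor, so it stands closer to the halophenyl compounds than to compound 3, and most of the compounds here sit at the limit of > 50000 nM in this assay, at which 2 of the 3 values shown sit. Compound 4 is therefore expected to remain near the limit, with a step that the limit leaves unreadable from compound 1 to compound 4. The estimate for compound 4 in this assay is 60000 nM, within a range from 15000 nM to 200000 nM.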

Compound 4, half-maximal inhibitory concentration: > 50000 nM
Compound 4 gave a limit, no number; the forecaster's own chance of this, stated with the estimate: 65%; the middle value lies beyond the limit too.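

In this assay compound 4 gives only a limit, and it carries neither chlorine nor bromine, so among the compounds shown the lack of a readable number is not confined to the halophenyl groups. All the steps among compound 1, compound 2 and compound 4 join limits and cannot be read, so nothing can be said about any order among these three. Setting the 3,4-dimethylphenyl group against the 3-sulfamoylphenyl group gives an at least 4.4-fold higher number from compound 3 to compound 4 (0.64 log units; beyond the scatter), which leaves compound 3, the one exception, as the only compound here with a measured number, while the others share a single ceiling: the limit of > 50000 nM in this assay, at which 3 of the 4 values shown sit.

The compounds shown leave open whether the readable number of compound 3 belongs to the sulfamoyl group itself or would also appear with a carboxylic acid or an amine on the same phenyl ring. They also leave open how far the true values of compound 1, compound 2 and compound 4 lie from one another, and whether a number well below that of compound 3 can be reached by a change at this position.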